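Swapping cyclopropyl for 2,4-difluorophenyl on the aromatic nitrogen

This account rests on a few compounds, and the source may have more. Where it says the series, first, only, none or still open, it means among the compounds named here.

For the measured compounds named here, only two compounds have been measured so far in a functional assay on V79 cells (Cricetulus griseus) for cytotoxicity, read by colony formation; a lower number here means a stronger inhibitor, a higher number a weaker inhibitor. Compound 2 (`CC1CN(c2c(F)cc3c(=O)c(C(=O)O)cn(C4CC4)c3c2Cl)CCN1`) gives 45 ug/mL, the lower number of the pair and so the stronger result, and the gap to compound 1 (`CCNCC1CCN(c2c(F)cc3c(=O)c(C(=O)O)cn(-c4ccc(F)cc4F)c3c2Cl)C1`), at 130 ug/mL, lies beyond the usual scatter.

Compound 3 (`CC1CN(c2c(F)cc3c(=O)c(C(=O)O)cn(-c4ccc(F)cc4F)c3c2Cl)CCN1`) keeps everything in compound 2 except one group, with 2,4-difluorophenyl in place of cyclopropyl on an aromatic nitrogen. Going by the values given here, no measured pair differs in one place alone, so this change has no direct precedent. Among the compounds with values here, the only guide is compound 1, which carries the same 2,4-difluorophenyl and gives 130 ug/mL, although it differs elsewhere too. A modest expected rise in this assay, toward weaker inhibition, is therefore a 2.2-fold higher number from compound 2 to compound 3 (0.35 log units; beyond the scatter). For compound 3 the estimated value is 100 ug/mL, with an expected range of 40 ug/mL to 250 ug/mL.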

Compound 3, half-maximal inhibitory concentration: > 500 ug/mL
Compound 3 gave a limit, no number; the forecaster's own chance of this, stated with the estimate: 10%; at least 5.0-fold (0.69 log units) between middle value and limit.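

In this assay compound 3 gives > 500 ug/mL, which is a limit and not a number. For the compounds shown here, with the 3-methylpiperazin-1-yl group held fixed, 2,4-difluorophenyl in place of cyclopropyl on the aromatic nitrogen gives an at least 11-fold higher number from compound 2 to compound 3 (1.04 log units; beyond the scatter), the first direct reading of this position, and it is a large move toward weaker inhibition. With 2,4-difluorophenyl held fixed, 3-methylpiperazin-1-yl in place of 3-((ethylamino)methyl)pyrrolidin-1-yl on an aromatic carbon gives an at least 3.8-fold higher number from compound 1 to compound 3 (0.58 log units; beyond the scatter), so that group matters as well, and the true size of both steps stays unknown: the limit of > 500 ug/mL in this assay, at which 1 of the 3 values shown sits.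

From the compounds shown here alone, each change rests on a single pair, so it remains open whether the cyclopropyl step would hold with a different amine on the aromatic carbon. Going by these compounds, it is also open where an ethyl group or an unsubstituted phenyl on the aromatic nitrogen would fall relative to compound 2 and compound 3.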